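This account rests on a few compounds, and the source may have more. Where it says the series, first, only, none or still open, it means among the compounds named here.

Measured so far in a functional assay on CHO cells for agonist activity at Melanocyte-stimulating hormone receptor (Homo sapiens), read by a luciferase reporter, with a stated time of 4 h; a higher number here means that more compound is needed for the effect, a lower number that less compound is needed:
- compound 1 `COc1ccc(N(C(=O)CN2C=CN(Cc3ccccc3)C(=O)C(Cc3n[nH]c4ccccc34)C2=O)C(C)C)cc1`: 794 nM
- compound 2 `CC(C)N(C(=O)CN1C=CN(c2ccccc2)C(=O)C(Cc2n[nH]c3ccccc23)C1=O)c1ccc(F)cc1`: 50.1 nM
- compound 3 `CC(C)N(C(=O)CN1C=CN(c2ccccc2)C(=O)[C@H](Cc2n[nH]c3cc(F)ccc23)C1=O)c1ccccc1`: 35.5 nM

Compound 2 holds the second highest number of the three. Its nearest neighbour is compound 3, whose value lies within the scatter of that of compound 2, so the two cannot be ordered. Compound 1 stands far higher, beyond the scatter, and differs from compound 2 in more than one place, so no single step can be read from that pair.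

Compound 4 `O=C1C(Cc2n[nH]c3ccccc23)C(=O)N(c2ccccc2)C=CN1CC(=O)N1CCCCc2ccccc21` has not been measured. Relative to compound 2 it carries a group of 11 heavy atoms (10 carbon, 1 nitrogen; one six-membered aromatic ring of carbon only, one seven-membered non-aromatic ring with 1 hetero atom) in place of a group of 11 heavy atoms (9 carbon, 1 nitrogen, 1 fluorine; one six-membered aromatic ring of carbon only), on a carbonyl carbon. For the measured compounds named here, no measured pair shows a change of this kind, so the direction of the step in this assay is open. The shared core of compound 2 and compound 3 is kept intact in compound 4, which argues against a large move; a modest rise in the number, near the edge of the scatter, is taken as the more likely outcome.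

Compound 4 is therefore expected to give 110 nM, with a range from 25 nM to 450 nM, an estimated step of a 2.2-fold higher number from compound 2 to compound 4 (0.34 log units; beyond the scatter).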

Compound 4, half-maximal effective concentration: 1.59 nM
The estimate for compound 4 lay 69-fold (1.84 log units) above the measured number, and the stated range ends above it.
By their numbers in this assay, from the lowest: compound 4; then compounds 3 and 2 (each within the scatter of the next); then compound 1.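

In this assay, the group on the carbonyl carbon proves to be a strong handle on the number: the group with one six-membered aromatic ring of carbon only gives way to one that also holds one seven-membered non-aromatic ring with 1 hetero atom, for a 32-fold lower number from compound 2 to compound 4 (1.50 log units; beyond the scatter). Both groups have 11 heavy atoms, so a large step occurs here with no change in that count, while the fluorine of the leaving group is lost and the added ring is gained in the same step. Nothing available bears on the reason for a step of this size.

For the compounds shown here, the single step cannot separate the loss of fluorine from the ring closure. Also open, on these data alone, is how this position would respond to a pyrrolidine, a piperidine or a group carrying a carboxylic acid.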